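A Second Hydroxyl on the Side Chain of a Shared Core

The source may report more compounds than this note shows. Statements on the series, on what has been measured and on what is new or still open speak of the compounds shown alone.

Measured compounds in a functional assay on CCRF-CEM cells (Homo sapiens) for antiproliferative activity, read by MTT assay, with a stated time of 24 h, tested at 100 uM; a lower number here means a stronger effect, a higher number a weaker effect of the compound at the concentration tested:
- compound 1 `C[C@@H](O)CCn1nc2c(Br)c(Br)c(Br)c(Br)c2n1` gives 36%
- compound 2 `C[C@H](O)CCn1nc2c(Br)c(Br)c(Br)c(Br)c2n1` gives 36%
- compound 3 `CC(O)CCn1nc2c(Br)c(Br)c(Br)c(Br)c2n1` gives 3%

Compound 3 stands lowest of the three numbers; its nearest neighbour is compound 1, and compound 2 sits at the same distance, both beyond the scatter. The measured steps are all about configuration only: no change at the digits printed from compound 1 to compound 2 (within the scatter), which fits (the fact that compounds 1 and 2 differ only in the configuration as drawn), while a number 33 percentage points lower from compound 1 to compound 3 (beyond the scatter) and a number 33 percentage points lower from compound 2 to compound 3 (beyond the scatter) go with the fact that one of compounds 1 and 3 is drawn with a defined configuration and the other without, at the place where they differ and (the fact that one of compounds 2 and 3 is drawn with a defined configuration and the other without, at the place where they differ).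

Compound 4 `OCC(O)Cn1nc2c(Br)c(Br)c(Br)c(Br)c2n1` differs from compound 3 in another way: 1,2-dihydroxyethyl in place of 2-hydroxypropyl on a saturated chain carbon bound to an aromatic nitrogen. Among the measured compounds shown here, none of the measured steps changes any atom or bond, so none of them bears directly on this swap, and the size of the step in this assay can only be guessed. Compound 3 is the strongest point measured, and a change of the chain is expected to move the number, most likely upward, by a number 17 percentage points higher from compound 3 to compound 4 (beyond the scatter). Compound 4 is therefore estimated at 20%, in a range from 2% to 45%.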

Compound 4, a percentage reported as activity, at one concentration (the size of the read-out at that concentration, not a potency): 8%
Compound 4: middle estimate off by 12 percentage points, on the high side, within the range that was stated.
By their numbers in this assay, from the lowest: compounds 3 and 4 (each within the scatter of the next); then compounds 1 and 2 (each within the scatter of the next).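

In this assay, among the compounds shown here, this is the first change of atoms at this position rather than of configuration, and 1,2-dihydroxyethyl in place of 2-hydroxypropyl gives a number 5 percentage points higher from compound 3 to compound 4 (within the scatter), so the second hydroxyl leaves the side chain's effect indistinguishable from that of compound 3. Read against the compounds drawn with a defined configuration, the same swap gives a number 28 percentage points lower from compound 2 to compound 4 (beyond the scatter) and a number 28 percentage points lower from compound 1 to compound 4 (beyond the scatter), which places compound 4 alongside compound 3 rather than with those two. Nothing at hand explains why the second hydroxyl is tolerated here.

As far as these compounds go, it remains open how the number would respond to an amine or a carboxylic acid in place of the second hydroxyl, or to a longer chain carrying both hydroxyls. From the compounds shown here alone, compound 4 is drawn without a configuration, so how forms of it with a defined configuration would read also stays open.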